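The compounds below may be only part of what the source reports. "The series", "measured", "known", "first", "only" and "open" are said of these compounds alone.

In an ADME assay on microsomes from liver (Mus musculus) for metabolic stability, read by LC-MS, with a stated time of 10 min, tested at 0.5 uM (a lower number here means that less of the compound is left, a higher number that more of the compound is left), compound 1 (`c1ccc2c(c1)CN[C@@H](CN(CC1CCNCC1)[C@H]1CCCc3cccnc31)C2`) gives 13%, compound 2 (`c1ccc2c(c1)CN[C@@H](CN(CCCN1CCNCC1)[C@H]1CCCc3cccnc31)C2`) gives 92% and compound 3 (`c1ccc2c(c1)CN[C@@H](CN(CCC1CCNCC1)[C@H]1CCCc3cccnc31)C2`) gives 32%. Compound 3 therefore stands second highest of the three. The next structure is compound 4 (`CCN1CCN(CCCN(C[C@H]2Cc3ccccc3CN2)[C@H]2CCCc3cccnc32)CC1`), and the change to it is (4-ethylpiperazin-1-yl)methyl in place of piperidin-4-yl on a saturated chain carbon, two bonds along the chain from an amine nitrogen.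

The closest evidence is a number 60 percentage points lower from compound 2 to compound 3 (beyond the scatter), a large step that swaps (piperazin-1-yl)methyl for piperidin-4-yl at the same place, so it runs opposite to the present change. Also relevant are a number 79 percentage points higher from compound 1 to compound 2 (beyond the scatter), which is large, and a number 19 percentage points higher from compound 1 to compound 3 (beyond the scatter), which is modest. Among the measured compounds shown here, no measured compound carries (4-ethylpiperazin-1-yl)methyl, so the effect of the added ethyl is unknown and the gain seen with compound 2 cannot be carried over in full. In this assay, a large upward step is still expected, estimated as a number 40 percentage points higher from compound 3 to compound 4 (beyond the scatter). For compound 4, the estimated value is 72%, with an expected range of 45% to 93%.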

Compound 4, percent of the compound remaining: 19%
Estimate against measurement, compound 4: 53 percentage points above, outside the stated range (below it).
By their numbers in this assay, from the lowest: compounds 1 and 4 (each within the scatter of the next); then compound 3; then compound 2.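

In this assay, ethyl in place of hydrogen on an amine nitrogen in a ring gives a number 73 percentage points lower from compound 2 to compound 4 (beyond the scatter), so the large gain seen earlier for the piperazine side chain does not survive this single addition. The piperazine ring alone therefore does not secure a high value: (4-ethylpiperazin-1-yl)methyl in place of piperidin-4-yl gives a number 13 percentage points lower from compound 3 to compound 4 (beyond the scatter), while the comparison with the shortest side chain gives a number 6 percentage points higher from compound 1 to compound 4 (within the scatter). No measurement shown here accounts for the effect of the ethyl group.

From the compounds shown here alone, whether this loss is specific to ethyl or extends to other groups on that ring nitrogen stays open; methyl, 2-hydroxyethyl and acetyl would test this. Also open, going by these compounds, is whether ethyl on the piperidine nitrogen of compound 3 would change the value in the same direction.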